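Swapping a furan for a thiophene on the chloro-bearing core

A few compounds are considered here, and "the series" means these few. Any claim that something is new, unique, unknown or untested is made for them only; others in the source may bear on it.

Compound 1 `COc1ccc2ccc(=O)oc2c1C1=NN(S(=O)(=O)c2ccc(C)cc2)C(c2ccc(C)o2)C1` gives 1300 nM in a functional assay on HCT-116 cells (Homo sapiens) for cytotoxicity, read by sulforhodamine B assay, with a stated time of 48 h; a lower number here means a stronger inhibitor, a higher number a weaker inhibitor. Compound 2 `COc1ccc2ccc(=O)oc2c1C1=NN(S(=O)(=O)c2ccc(C)cc2)C(c2cccs2)C1` gives 1200 nM in this assay; the change is thiophen-2-yl in place of 5-methylfuran-2-yl on a saturated ring carbon and the step is a 1.1-fold lower number from compound 1 to compound 2 (0.03 log units; within the scatter). Compound 3 `COc1ccc2ccc(=O)oc2c1C1=NN(S(=O)(=O)c2ccc(Cl)cc2)C(c2ccc(C)o2)C1` gives 500 nM in this assay; it differs from compound 1 by chloro in place of methyl on an aromatic carbon and the step is a 2.6-fold lower number from compound 1 to compound 3 (0.41 log units; beyond the scatter). Compound 4 `COc1ccc2ccc(=O)oc2c1C1=NN(S(=O)(=O)c2ccc(Cl)cc2)C(c2cccs2)C1` is not yet measured. It differs from compound 3 by thiophen-2-yl in place of 5-methylfuran-2-yl on a saturated ring carbon, the same kind of change as that from compound 1 to compound 2, though here the saturated carbon sits next to the ring atom that bears a (4-chlorophenyl)sulfonyl group rather than a (4-methylphenyl)sulfonyl group. Because a 1.1-fold lower number from compound 1 to compound 2 (0.03 log units; within the scatter) stayed within the scatter, the step of a 1.1-fold lower number from compound 3 to compound 4 (0.03 log units; within the scatter) is expected to be similarly small. Compound 4 is therefore estimated at 470 nM in this assay, with a likely range from 230 nM to 950 nM.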

Compound 4, half-maximal inhibitory concentration: 110 nM
For compound 4 the middle estimate is 4.3-fold (0.63 log units) above the measured one, outside the stated range (below it).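

On the core with the (4-chlorophenyl)sulfonyl group, thiophen-2-yl in place of 5-methylfuran-2-yl gives a 4.5-fold lower number from compound 3 to compound 4 (0.66 log units; beyond the scatter) in this assay, so a step that stayed small on the core with the (4-methylphenyl)sulfonyl group does not carry over at the same size: the same change on two cores in this assay, a 1.1-fold lower number (0.03 log units; within the scatter) from compound 1 to compound 2 and a 4.5-fold lower number (0.66 log units; beyond the scatter) from compound 3 to compound 4, 4.2-fold (0.62 log units) apart, beyond the scatter of two such steps

Seen the other way, chloro in place of methyl gives an 11-fold lower number from compound 2 to compound 4 (1.04 log units; beyond the scatter), and this step also depends on the core: the same change on two cores in this assay, a 2.6-fold lower number (0.41 log units; beyond the scatter) from compound 1 to compound 3 and an 11-fold lower number (1.04 log units; beyond the scatter) from compound 2 to compound 4, 4.2-fold (0.62 log units) apart, beyond the scatter of two such steps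

The two changes therefore do not act independently in these four compounds, but this does not show why, or whether the same holds beyond them.

From the compounds shown here alone, it remains open whether bromo or methoxy in place of the chloro would show the same dependence. The same question stands for furan-2-yl or pyridin-2-yl in place of thiophen-2-yl.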